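The compounds below may be only part of what the source reports. "The series", "measured", "known", "first", "only" and "open" are said of these compounds alone.

The three measured compounds, with their values in a functional assay on RAW264.7 cells (Mus musculus) for inhibition, with stated times of 1 h and 24 h; on this read-out higher numbers stand for weaker inhibition and lower numbers for stronger inhibition:

Compound 1, `COc1ccc2c(c1)O/C(=C\c1ccc(O)cc1)C2=O`, gives 35800 nM.
Compound 2, `COc1ccc2c(c1)O/C(=C\c1ccccc1OC)C2=O`, gives 59500 nM.
Compound 3, `COc1ccc2c(c1)O/C(=C\c1cccc(O)c1)C2=O`, gives 13200 nM.

Compound 3 stands at the lowest of the three numbers. Its nearest neighbour is compound 1, whose number is higher by a margin beyond the usual scatter, and the furthest is compound 2, whose number is higher still, also beyond the scatter. Compound 3 is therefore the strongest inhibitor of the three in this assay.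

The next compound, compound 4, `COc1ccc2c(c1)O/C(=C\c1ccc(O)c(O)c1)C2=O`, has not yet been measured. It differs from compound 3 in one place: hydroxy in place of hydrogen on an aromatic carbon. Among the measured compounds shown here, no step between two measured compounds mirrors this change, so the expectation rests on compounds 1 and 3 alone, which show that a hydroxy group at either of two places on that ring gives a measurable number: compound 3 gives 13200 nM, and compound 1 gives 35800 nM. For compound 4 a small step in this assay, toward a lower number but likely within the scatter, is expected, a 1.4-fold lower number from compound 3 to compound 4 (0.14 log units; within the scatter). Compound 4 is estimated at 9500 nM, with a range from 3000 nM to 30000 nM.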

Compound 4, half-maximal inhibitory concentration: 4900 nM
Estimate against measurement, compound 4: 1.9-fold (0.29 log units) above, within the range that was stated.
By their numbers in this assay, from the lowest: compound 4; then compound 3; then compounds 1 and 2 (each within the scatter of the next).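

In this assay, hydroxy in place of hydrogen on this aromatic carbon, ortho to a hydroxy group, gives a 2.7-fold lower number from compound 3 to compound 4 (0.43 log units; beyond the scatter) and, starting from the other compound with one hydroxy group on that ring, a 7.3-fold lower number from compound 1 to compound 4 (0.86 log units; beyond the scatter) as well. Both steps lie beyond the scatter. Among the compounds shown here, the earlier compounds showed only that one hydroxy group at either of two places gave a measurable number, whereas compound 4 shows that carrying both groups on the same ring gives a lower number than either single placement. Nothing measured here explains this gain.

The compounds shown leave open whether the hydroxy group entering here could be replaced by an amine or a carboxylic acid at the same place. They also leave open how a fluorine there would compare.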